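A few compounds are considered here, and "the series" means these few. Any claim that something is new, unique, unknown or untested is made for them only; others in the source may bear on it.

Three compounds of the series share the same core and differ only in the group carried on the five-membered aromatic ring with one sulfur. Compound 1 `CCCCc1csc(CN[C@@H]2C[C@H]3C[C@@H]([C@H]2C)C3(C)C)c1` carries a butyl there; in an ADME assay on MDCK cells (Canis lupus familiaris) for cytotoxicity, read by microscopy, with a stated time of 48 h (a lower number here means that less compound is tolerated, a higher number that more compound is tolerated), compound 1 gives 12500 nM. Compound 2 `Cc1ccsc1CN[C@@H]1C[C@H]2C[C@@H]([C@H]1C)C2(C)C` gives 10000 nM in this assay, and compound 3 `CSc1ccc(CN[C@@H]2C[C@H]3C[C@@H]([C@H]2C)C3(C)C)s1` gives 25000 nM. Compound 1 thus stands second highest of the three numbers; its nearest neighbour is compound 2 and its furthest is compound 3, and both of those gaps lie within the usual scatter, so the three values cannot be told apart.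

Compound 4 `C[C@H]1[C@H](NCc2cc(C3CC3)cs2)C[C@H]2C[C@@H]1C2(C)C` is not yet measured. Against compound 1 the change is cyclopropyl in place of butyl on an aromatic carbon. Among the compounds with values here, no measured pair shows this kind of exchange, so nothing in the data fixes its size or direction. Given that the three measured compounds all sit within scatter of one another, the expected step is no change at the digits printed from compound 1 to compound 4 (within the scatter), none beyond the scatter. Compound 4 is therefore estimated at 12500 nM in this assay, with a range from 5000 nM to 30000 nM.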

Compound 4, minimum cytotoxic concentration: 25000 nM
Beside the measured number, compound 4's estimate is 2.0-fold (0.30 log units) below it; the range from low to high includes it.
By their numbers in this assay, from the lowest: compounds 2, 1, 3 and 4 (each within the scatter of the next, the first and the last beyond it).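

In this assay, replacing butyl with cyclopropyl on an aromatic carbon, two ring bonds from the ring sulfur, gives a 2.0-fold higher number from compound 1 to compound 4 (0.30 log units; within the scatter). Within the data shown here, this is the first pair that differs in one place, and it shows that at this position an open chain and a three-membered carbon ring cannot be told apart in this read-out. The data give no cause for this result and offer no measured property of either group that bears on it.

From the compounds shown here alone, whether an amine, a carboxylic acid or a chain longer than butyl at this same carbon would give a step beyond the scatter remains open. Also open, going by these compounds, is whether the same exchange of butyl for cyclopropyl would give a similar step at another carbon of the five-membered aromatic ring.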